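Bromothiophene Sulfonyl in Place of Methoxyphenyl Sulfonyl

This account rests on a few compounds, and the source may have more. Where it says the series, first, only, none or still open, it means among the compounds named here.

Compound 1 `COc1ccc(-c2cc(=O)c3c(OC)cc(OC)cc3n2S(=O)(=O)c2ccc(C#N)cc2)cc1`: 7900 nM
Compound 2 `COc1ccc(-c2cc(=O)c3c(OC)cc(OC)cc3n2S(=O)(=O)c2ccc(Cl)cc2)cc1`: > 34400 nM
Compound 3 `COc1ccc(-c2cc(=O)c3c(OC)cc(OC)cc3n2S(=O)(=O)c2ccc(OC)cc2)cc1`: > 82700 nM

Three compounds share one core and differ only in the group on the sulfonyl sulfur. In a functional assay on SUP-B15 cells (Homo sapiens) for antiproliferative activity, with a stated time of 72 h (on this read-out lower numbers stand for an effect already at smaller amounts and higher numbers for an effect only at larger amounts of compound), compound 1 gives 7900 nM. For compound 2 this assay reports only a limit, > 34400 nM. For compound 3 this assay likewise reports only a limit, > 82700 nM, so compound 3 stands at the weak end of the shown values, with no number of its own. The step of an at least 10-fold higher number from compound 1 to compound 3 (1.01 log units; beyond the scatter) is large, the step of an at least 4.3-fold higher number from compound 1 to compound 2 (0.63 log units; beyond the scatter) is at least modest, and the step that the two limits leave unreadable from compound 2 to compound 3 cannot be read because both ends are limits.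

Compound 4 `COc1ccc(-c2cc(=O)c3c(OC)cc(OC)cc3n2S(=O)(=O)c2ccc(Br)s2)cc1` arises from compound 3 by the change (5-bromothiophen-2-yl in place of 4-methoxyphenyl on a sulfonyl sulfur). Among the measured compounds shown here, none of the measured steps concerns a thiophene, so they bear on this change only in that every exchange of the group on the sulfonyl sulfur moved this assay by a readable amount. Compound 3 sits at a limit, so any change seen would be toward a lower number. The author therefore expects compound 4 at 30000 nM, with a range from 7000 nM to 100000 nM, which means an estimated step of an at least 2.7-fold lower number from compound 3 to compound 4 (0.44 log units; beyond the scatter).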

Compound 4, half-maximal effective concentration: > 48200 nM
Compound 4: only a limit was reported; the forecaster's own chance of this, stated with the estimate: 50%; at least 1.6-fold (0.20 log units) between middle value and limit.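

Placing the 5-bromothiophen-2-yl group on the sulfonyl sulfur is the first exchange here that replaces the six-membered carbon ring, and in this assay the comparison with the 4-cyanophenyl group gives an at least 6.1-fold higher number from compound 1 to compound 4 (0.78 log units; beyond the scatter) and so does not recover the value of compound 1. Compound 4 therefore joins compound 2 and compound 3 as a compound with only a limit, which leaves the 4-cyanophenyl group of compound 1 as the only group shown with a number of its own. The exchange of the 4-methoxyphenyl group in compound 3 and of the 4-chlorophenyl group in compound 2 for the 5-bromothiophen-2-yl group cannot be read, as both ends of each step are limits, so these three compounds cannot be placed in any order.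

From the compounds shown here alone, it remains open whether the thiophene ring itself or its bromine accounts for the result, which a 5-cyanothiophen-2-yl group or an unsubstituted thiophen-2-yl group on the sulfonyl sulfur would address. Also open, going by these compounds, is how a 4-aminophenyl or 4-carboxyphenyl group would behave in this place.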